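Replacing a Fluorine by a Phenyl on the Benzyl Arm

This account rests on a few compounds, and the source may have more. Where it says the series, first, only, none or still open, it means among the compounds named here.

Compound 1, `O=C(NO)c1cnc(N2C[C@@H]3[C@H](C2)[C@H]3NS(=O)(=O)c2cccs2)nc1`, gives > 10000 nM in a functional assay on HCT-116 cells (Homo sapiens) for antiproliferative activity, read by WST assay, with a stated time of 72 h (a lower number here means a stronger inhibitor of growth, a higher number a weaker inhibitor of growth), which is a limit of the assay and not a number.
Compound 2, `O=C(NO)c1cnc(N2C[C@@H]3[C@H](C2)[C@H]3NC(=O)c2cccs2)nc1`, gives 3600 nM in this assay.
Compound 3, `O=C(NO)c1cnc(N2C[C@@H]3[C@H](C2)[C@H]3NCc2ccc(F)cc2)nc1`, gives 380 nM in this assay.

The three measured compounds share one core and differ only in the group carried on the amine nitrogen. Among the two numbers that are actual values, compound 3 stands lowest, with compound 2 the nearest at a 9.5-fold lower number from compound 2 to compound 3 (0.98 log units; beyond the scatter). The move an at least 2.7-fold lower number from compound 1 to compound 2 (0.44 log units; beyond the scatter) and the move an at least 26-fold lower number from compound 1 to compound 3 (1.42 log units; beyond the scatter) rest on a limit, as the limit of > 10000 nM in this assay, at which 1 of the 3 values shown sits, records, so only their direction is secure.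

Compound 4, `O=C(NO)c1cnc(N2C[C@@H]3[C@H](C2)[C@H]3NCc2ccc(-c3ccccc3)cc2)nc1`, keeps the benzyl arm of compound 3 and changes it in one place: phenyl in place of fluoro on an aromatic carbon. Among the compounds with values here, none of the measured steps touches that position; all three swap the whole group on the amine nitrogen, and each of them gave a modest or large step. The smaller change here gives no ground to expect a step of that size, so a move within or near the scatter is expected, with some room on either side. For compound 4 a value of 350 nM is expected, within 100 nM to 1200 nM, meaning an expected step of a 1.1-fold lower number from compound 3 to compound 4 (0.04 log units; within the scatter).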

Compound 4, concentration for 50% growth inhibition: 56 nM
For compound 4 the middle estimate is 6.3-fold (0.80 log units) above the measured one, and the stated range ends above it.
By their numbers in this assay, from the lowest: compound 4; then compound 3; then compound 2. At a limit, above all of these: compound 1.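

Putting phenyl in place of fluoro on an aromatic carbon, para to a large group, gives a 6.8-fold lower number from compound 3 to compound 4 (0.83 log units; beyond the scatter) in this assay, which shows that this one position on the benzyl arm can shift growth inhibition on its own. The earlier steps shown here all swapped the whole group on the amine nitrogen, so they could not show whether a change confined to the far end of the arm would register; here it does, and a full aromatic ring of six carbons is accepted in place of a single fluorine, with a stronger inhibitor as the result. Nothing measured here bears on why this swap lowers the number.

The compounds shown leave open whether an aromatic ring is needed at this position or whether other larger groups would serve as well, a question that a cyclohexyl group, a methoxy group or a carboxylic acid in the same place would address. They also leave open whether an added phenyl would give a similar step on the thiophene ring of compound 2.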